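Compound 1 to compound 4: a step at the limit

The source may hold more compounds than are shown below. What is called first, only, known or untested is meant among the compounds shown, and "the series" means these compounds.

In an ADME assay on CEM-SS cells (Homo sapiens) for cytotoxicity, read by XTT assay (on this read-out lower numbers stand for higher toxicity in this test and higher numbers for lower toxicity in this test), compound 1 (`CN(O)C(=O)c1cc2c(CN3CCC(O)C3)cn(Cc3ccc(F)cc3)c2cn1`) gives > 100000 nM, which is a limit of the assay and not a number. Compound 2 (`COCCOCc1cn(Cc2ccc(F)cc2)c2cnc(C(=O)N(C)O)cc12`) gives > 100000 nM, also a limit. Compound 3 (`CN(O)C(=O)c1cc2c(COC3CCOCC3)cn(Cc3ccc(F)cc3)c2cn1`) gives > 100000 nM, again a limit. Compound 1 therefore has no numerical position in the series: the limit of > 100000 nM in this assay, at which 3 of the 3 values shown sit.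

Compound 4 (`CCOCCOCc1cn(Cc2ccc(F)cc2)c2cnc(C(=O)N(C)O)cc12`) remains unmeasured. Its difference from compound 1 is 2-ethoxyethoxy in place of 3-hydroxypyrrolidin-1-yl on a saturated chain carbon bound to an aromatic carbon. In words, this is 2-ethoxyethoxy in place of 3-hydroxypyrrolidin-1-yl on a saturated chain carbon bound to an aromatic carbon.

The closest measured change is a step that the two limits leave unreadable from compound 1 to compound 2, with 2-methoxyethoxy entering at the same place. The other two measured changes are a step that the two limits leave unreadable from compound 1 to compound 3 and a step that the two limits leave unreadable from compound 2 to compound 3. None of the three has a readable size, so they provide no direction and no magnitude to carry over. No step beyond the scatter is expected in this assay, and a further reading at the limit is the most likely outcome.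

For compound 4 the estimated value is 100000 nM, with an expected range of 50000 nM to 200000 nM. The estimate corresponds to an expected a number no higher from compound 1 to compound 4 (the limit leaves the size open).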

Compound 4, half-maximal cytotoxic concentration: 81000 nM
Compound 4: middle estimate off by 1.2-fold (0.09 log units), on the high side; low and high end bracket the measured number.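

In this assay, among these compounds, compound 4 gives 81000 nM, the first reading at this place on a saturated chain carbon bound to an aromatic carbon that is a number and not a limit. The change to 2-ethoxyethoxy gives an at least 1.2-fold lower number from compound 1 to compound 4 (0.09 log units; that floor lies within the scatter), and the comparisons with the two ether neighbours give an at least 1.2-fold lower number from compound 3 to compound 4 (0.09 log units; that floor lies within the scatter) and an at least 1.2-fold lower number from compound 2 to compound 4 (0.09 log units; that floor lies within the scatter); each is only a floor, and each floor lies within the usual scatter, so none of the three establishes a real drop in the read-out, including the single added methyl of the last step. The steps among compound 1, compound 2 and compound 3 cannot be read, and most of the set still gives no number: the limit of > 100000 nM in this assay, at which 3 of the 4 values shown sit.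

From the compounds shown here alone, how far compound 1, compound 2 and compound 3 truly stand from compound 4 remains open, as their true values lie beyond the reach of this read-out. Also open, going by these compounds, is whether a longer chain such as 2-propoxyethoxy, or a basic amine such as piperidin-1-yl, at this place would give a number clearly beyond the scatter from compound 4.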